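Trimming a phenyl from the most potent analogue

The compounds below may be only part of what the source reports. "The series", "measured", "known", "first", "only" and "open" are said of these compounds alone.

Measured compounds:
- compound 1, `CC(C)C[C@H](N)C(=O)NS(=O)(=O)c1cccc(-c2ccncc2)c1`: 1200 nM
- compound 2, `CC(C)C[C@H](N)C(=O)NS(=O)(=O)c1cccc(-c2cc(-c3ccccc3)nc(N)n2)c1`: 33 nM

The series was tested in an assay on isolated protein for inhibition of leucine--tRNA ligase, cytoplasmic (Homo sapiens); on this read-out lower numbers stand for stronger inhibition and higher numbers for weaker inhibition. Compound 1 gives 1200 nM in this assay, while compound 2 gives 33 nM. Of the two numbers, compound 2 holds the lowest; compound 1 stands at a markedly higher number, and that gap lies well beyond the usual scatter. The two structures differ in more than one place, so only their two values can be compared, not a single step.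

Compound 3, `CC(C)C[C@H](N)C(=O)NS(=O)(=O)c1cccc(-c2ccnc(N)n2)c1`, has not yet been measured in this assay. Relative to compound 2 it carries hydrogen in place of phenyl on an aromatic carbon. The phenyl is the largest piece that separates compound 2 from compound 1, so its loss is expected to move the number upward, though compound 3 keeps the amino-bearing ring of compound 2 and should remain apart from compound 1. The step from compound 2 to compound 3 is therefore estimated at a 7.6-fold higher number from compound 2 to compound 3 (0.88 log units; beyond the scatter), beyond the scatter. For compound 3 the expected value is 250 nM, with a range from 60 nM to 1000 nM.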

Compound 3, half-maximal inhibitory concentration: 3900 nM
Compound 3: the middle estimate sits 16-fold (1.19 log units) below what was measured; measured number above the stated range.
By their numbers in this assay, from the lowest: compound 2; then compound 1; then compound 3.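

In this assay, the phenyl on this aromatic carbon turns out to carry most of what compound 2 has, since replacing it with hydrogen gives a 120-fold higher number from compound 2 to compound 3 (2.07 log units; beyond the scatter), a large step that leaves compound 3 with the highest number of the three. The 2-aminopyrimidin-4-yl ring on its own therefore offers no gain: put in place of pyridin-4-yl, it gives a 3.3-fold higher number from compound 1 to compound 3 (0.51 log units; beyond the scatter), a modest step in the unfavourable direction, so the low number of compound 2 cannot be credited to that ring without its phenyl. No independent measurement is available to explain why the phenyl matters so much here.

The compounds shown leave open whether a phenyl is specifically required on this carbon, or whether something smaller such as a methyl group, or a saturated ring such as cyclohexyl, would recover part of the step. They also leave open what the amino group contributes when the phenyl is present, which only a phenyl-bearing analogue with hydrogen in place of that amino group could show.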